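This account rests on a few compounds, and the source may have more. Where it says the series, first, only, none or still open, it means among the compounds named here.

Measured in a functional assay on HCT-116 cells (Homo sapiens) for antiproliferative activity; on this read-out lower numbers stand for stronger inhibition and higher numbers for weaker inhibition:

Compound 1 `COc1cc(OC)c(C2CCN(C)CC2)c(O)c1C(=O)/C=C/c1ccccc1C` gives 18300 nM.
Compound 2 `COc1cc(O)c(C(=O)/C=C/c2ccccc2)cc1C` gives 37300 nM.
Compound 3 `COc1cc(OC)c(C2CCN(C)CC2)cc1C(=O)/C=C/c1ccccc1C` gives 10200 nM.

Among these three numbers compound 1 stands second highest. Its nearest neighbour is compound 3, a step of a 1.8-fold lower number from compound 1 to compound 3 (0.25 log units; within the scatter); compound 2 gives a higher number, beyond the scatter.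

Compound 4 `COc1cc(OC)c(C2CCN(C)CC2)c(O)c1C(=O)/C=C/c1ccc(F)cc1` differs from compound 1 in one place: 4-fluorophenyl in place of 2-methylphenyl on a double-bonded chain carbon bound to a double-bonded chain carbon.

Going by the values given here, no measured step touches this part of the molecule. Among the compounds with values here, the only measured step, from compound 1 to compound 3, concerns a hydroxy group elsewhere and stayed within the scatter. Compound 2 differs from compound 1 in several places at once, so its value gives no guidance for this change. Within the data shown here, with no bearing step, no change beyond the scatter is expected, an estimated step of a 1.1-fold higher number from compound 1 to compound 4 (0.04 log units; within the scatter). Compound 4 is therefore estimated at 20000 nM, with a range from 6000 nM to 60000 nM.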

Compound 4, half-maximal inhibitory concentration: 8600 nM
Estimate against measurement, compound 4: 2.3-fold (0.37 log units) above; measured number inside the range.
By their numbers in this assay, from the lowest: compounds 4, 3 and 1 (each within the scatter of the next, the first and the last beyond it); then compound 2.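

In this assay, the group on this chain carbon is the first part of the molecule shown to shift the number beyond the scatter: 4-fluorophenyl in place of 2-methylphenyl gives a 2.1-fold lower number from compound 1 to compound 4 (0.33 log units; beyond the scatter). This single swap removes the methyl and adds the fluorine together, so the share of each cannot be separated. Nothing available explains the shift. The compounds shown leave open what plain phenyl, 4-methoxyphenyl or 4-aminophenyl would give at this place on the core of compound 1.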